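Trimming the Side Chain: an Estimate for Compound 4

A few compounds are considered here, and "the series" means these few. Any claim that something is new, unique, unknown or untested is made for them only; others in the source may bear on it.

Three compounds have been measured in an assay on isolated protein (urine) for inhibition of Myeloperoxidase (Homo sapiens), with a stated time of 5 min; on this read-out lower numbers stand for stronger inhibition and higher numbers for weaker inhibition:
compound 1 `NC(=O)CCCCc1c[nH]c2ccc(F)cc12`, 39 nM
compound 2 `NCC(N)CCc1c[nH]c2ccc(F)cc12`, 60 nM
compound 3 `CNC(=O)CCCc1c[nH]c2ccc(F)cc12`, 40 nM

Compound 3 gives the second highest of the three numbers, yet its gaps to both others stay within the scatter: a 1.0-fold higher number from compound 1 to compound 3 (0.01 log units; within the scatter) and a 1.5-fold lower number from compound 2 to compound 3 (0.18 log units; within the scatter). Compound 4 `NC(=O)CCc1c[nH]c2ccc(F)cc12` shortens the chain further: carbamoyl in place of (methylcarbamoyl)methyl on a saturated chain carbon, two bonds along the chain from an aromatic carbon. The one measured shortening, a 1.0-fold higher number from compound 1 to compound 3 (0.01 log units; within the scatter), changed nothing, and the other terminal swap, a 1.5-fold higher number from compound 1 to compound 2 (0.19 log units; within the scatter), also stayed within the scatter. This change removes more than any measured step did, so the expectation for compound 4 is a number near that of compound 3, with a wider margin of doubt, and the estimated step is a 1.5-fold higher number from compound 3 to compound 4 (0.18 log units; within the scatter). Compound 4 is therefore expected to give about 60 nM in this assay, between 25 nM and 150 nM.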

Compound 4, half-maximal inhibitory concentration: 132 nM
Compound 4: middle estimate off by 2.2-fold (0.34 log units), on the low side, and the stated range covers the measured number.
By their numbers in this assay, from the lowest: compounds 1, 3 and 2 (each within the scatter of the next); then compound 4.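

Unlike the earlier changes on this chain, the swap to carbamoyl moves the number beyond the scatter, and against all three other compounds: (a 3.3-fold higher number from compound 3 to compound 4 (0.52 log units; beyond the scatter)), (a 2.2-fold higher number from compound 2 to compound 4 (0.34 log units; beyond the scatter)) and (a 3.4-fold higher number from compound 1 to compound 4 (0.53 log units; beyond the scatter)). The earlier compounds sit within the scatter of one another, so the side chain can vary without a clear change, yet compound 4, with the shortest chain shown, gives a modestly higher number. Nothing available explains this rise. Going by these compounds, whether the shorter chain or the amide end matters more stays open, and a carboxylic acid or an amine on this same short chain would help separate the two.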